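The source may hold more compounds than are shown below. What is called first, only, known or untested is meant among the compounds shown, and "the series" means these compounds.

Measured so far in an assay on membranes from HeLa cells for displacement of a labelled ligand from adenosine receptor A3 (Homo sapiens), read by scintillation counting, with a stated time of 180 min, tested at 1 uM; on this read-out higher numbers stand for more inhibition at the one concentration tested (going by the name of the read-out) and lower numbers for less inhibition:
compound 1, `CC1=C(C(=O)OCC2CC2)C(c2ccco2)NC(=O)N1`, gives 1%
compound 2, `CC1=C(C(=O)OCC2CCC2)C(c2ccco2)NC(=O)N1`, gives 1%
compound 3, `CC1=C(C(=O)OCC2CC2)C(c2cccs2)NC(=O)N1`, gives 1%

Compound 4, `CC1=C(C(=O)OCC2CCC2)C(c2cccs2)NC(=O)N1`, has not yet been measured in this assay. It differs from compound 3 by one change, (cyclobutyl in place of cyclopropyl on a saturated chain carbon bound to an oxygen next to a carbonyl group). The same change has already been made once, from compound 1 to compound 2, as cyclobutyl in place of cyclopropyl on a saturated chain carbon bound to an oxygen next to a carbonyl group, and there it produced no change at the digits printed from compound 1 to compound 2 (within the scatter). The two cores differ in one place, (thiophen-2-yl in place of furan-2-yl on a saturated ring carbon), and that change gave no change at the digits printed from compound 1 to compound 3 (within the scatter). With all three measured compounds sitting within the scatter of one another at a very low level of inhibition, the step from compound 3 to compound 4 is expected to be no change at the digits printed from compound 3 to compound 4 (within the scatter), resting on no change at the digits printed from compound 1 to compound 2 (within the scatter). Compound 4 is therefore estimated to give 1%, most likely between -8% and 10%.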

Compound 4, a percentage reported as inhibition, at one concentration (the size of the read-out at that concentration, not a potency): 1%
Compound 4: middle estimate and measured number agree at the digits printed, and the stated range covers the measured number.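

In this assay, putting cyclobutyl in place of cyclopropyl gives no change at the digits printed from compound 3 to compound 4 (within the scatter), and putting thiophen-2-yl in place of furan-2-yl gives no change at the digits printed from compound 2 to compound 4 (within the scatter). The cyclobutyl change reads the same on both cores: the same change on two cores in this assay, no change at the digits printed (within the scatter) from compound 1 to compound 2 and no change at the digits printed (within the scatter) from compound 3 to compound 4, 0 percentage points apart, within the scatter of two such steps. The thiophen-2-yl change also repeats, but since none of these compounds shows more than a trace of inhibition, this cannot show whether either change would carry over on a core that inhibits clearly: the same change on two cores in this assay, no change at the digits printed (within the scatter) from compound 1 to compound 3 and no change at the digits printed (within the scatter) from compound 2 to compound 4, 0 percentage points apart, within the scatter of two such steps.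

The compounds shown leave open whether any group at these two places can raise the read-out at all. A phenyl ring in place of the furan-2-yl, or a longer chain or an amine in place of the cyclobutyl, remains to be seen.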